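This account rests on a few compounds, and the source may have more. Where it says the series, first, only, none or still open, it means among the compounds named here.

Compound 1 `COc1cc2c(Oc3ccc(NC(=O)c4cc(-c5ccc(F)cc5)on4)cc3)ccnc2cc1OCCCN1CCC(C)CC1` is tested in a functional assay on PC-3 cells (Homo sapiens) for antiproliferative activity, read by MTT assay, with a stated time of 72 h (a lower number here means a stronger inhibitor, a higher number a weaker inhibitor), where compound 1 gives 2040 nM. Among the three compounds measured so far, compound 1 stands second highest. Its two companions differ from it only in the five-membered ring that carries the fluorophenyl group: compound 2 `COc1cc2c(Oc3ccc(NC(=O)c4nc(-c5ccc(F)cc5)no4)cc3)ccnc2cc1OCCCN1CCC(C)CC1` gives 1040 nM, and compound 3 `COc1cc2c(Oc3ccc(NC(=O)c4nnc(-c5ccc(F)cc5)o4)cc3)ccnc2cc1OCCCN1CCC(C)CC1` gives 3810 nM. The steps of a 2.0-fold lower number from compound 1 to compound 2 (0.29 log units; within the scatter) and a 1.9-fold higher number from compound 1 to compound 3 (0.27 log units; within the scatter) both lie within the scatter, while the step of a 3.7-fold higher number from compound 2 to compound 3 (0.56 log units; beyond the scatter) is modest.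

Compound 4 `COc1cc2nccc(Oc3ccc(NC(=O)c4cc(-c5ccc(F)cc5)on4)cc3)c2cc1OC` keeps the five-membered ring of compound 1 and changes a different part: hydrogen in place of 2-(4-methylpiperidin-1-yl)ethyl on a saturated chain carbon bound to an oxygen on an aromatic ring. Among the compounds with values here, none of the measured steps touches this chain; they all concern the five-membered ring, so nothing measured here bears directly on the change, and neither its direction nor its size can be read from these three compounds. Without such a guide, compound 4 is expected to give 4000 nM, with a likely range from 1500 nM to 12000 nM. The step of a 2.0-fold higher number from compound 1 to compound 4 (0.29 log units; within the scatter) is thus estimated to be a mild weakening, but one that could well fall inside the scatter.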

Compound 4, half-maximal inhibitory concentration: 29400 nM
Beside the measured number, compound 4's estimate is 7.4-fold (0.87 log units) below it; measured number outside the range, above it.
By their numbers in this assay, from the lowest: compounds 2, 1 and 3 (each within the scatter of the next, the first and the last beyond it); then compound 4.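

Within the data shown here, replacing the 3-(4-methylpiperidin-1-yl)propoxy group with methoxy gives a 14-fold higher number from compound 1 to compound 4 (1.16 log units; beyond the scatter) in this assay, which shows that this position, untouched by the earlier compounds, strongly affects the read-out. This step is larger than the biggest listed change among the five-membered rings, a 3.7-fold higher number from compound 2 to compound 3 (0.56 log units; beyond the scatter) between those two ring variants, and in these compounds the side chain counts for more than the choice of ring. No measurement given here explains why removing the chain has this effect.

The compounds shown leave open whether the effect comes from the piperidine ring, its methyl group or the chain that carries it, since the whole group changes at once. A shorter chain ending in a dimethylamino group, or a morpholine ring in place of the 4-methylpiperidine, would help to separate these parts.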